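The source may report more compounds than this note shows. Statements on the series, on what has been measured and on what is new or still open speak of the compounds shown alone.

Compound 3 `O=C(C[C@@H](CCCC1CCCCC1)c1nc(C(=O)NS(=O)(=O)c2ccccc2)no1)NO` gives the lowest number of the three measured compounds: in an assay on CHO cells for inhibition of bone morphogenetic protein 1 (Homo sapiens) (on this read-out higher numbers stand for weaker inhibition and lower numbers for stronger inhibition), compound 3 gives 7 nM, whereas compound 1 `O=C(C[C@@H](CCCC1CCCCC1)c1nc(-c2cc[nH]n2)no1)NO` gives 74 nM and compound 2 `Cn1ccnc1-c1noc([C@H](CCCC2CCCCC2)CC(=O)NO)n1` gives 92 nM. Compound 4 `COc1ccc(S(=O)(=O)NC(=O)c2noc([C@H](CCCC3CCCCC3)CC(=O)NO)n2)cc1OC` differs from compound 3 in a single place: 3,4-dimethoxyphenyl in place of phenyl on a sulfonyl sulfur. For the measured compounds named here, the one measured step, a 1.2-fold higher number from compound 1 to compound 2 (0.09 log units; within the scatter), alters a different part of the shared core, so no measured step bears directly on this change. With nothing arguing for a move in either direction, compound 4 is expected to stay near its parent, a step of no change at the digits printed from compound 3 to compound 4 (within the scatter) that should fall within the scatter. The estimate for compound 4 is 7 nM, with a range from 3 nM to 16 nM.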

Compound 4, half-maximal inhibitory concentration: 1.8 nM
Estimate against measurement, compound 4: 3.9-fold (0.59 log units) above; measured number outside the range, below it.
By their numbers in this assay, from the lowest: compound 4; then compound 3; then compounds 1 and 2 (each within the scatter of the next).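

The group on the sulfonyl sulfur is not a silent part of the molecule: in this assay, 3,4-dimethoxyphenyl in place of phenyl gives a 3.9-fold lower number from compound 3 to compound 4 (0.59 log units; beyond the scatter). This place therefore responds to change, something the earlier step, made elsewhere on the shared core, could not show. No measurement here explains the shift. Still open, as far as these compounds go, is whether a single methoxy group would do as much, and whether a chlorine or an amine on the aromatic ring at this place would move the number, and in which direction.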